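Swapping a Nitrile for Bromine on the Aryl Ring

The source may report more compounds than this note shows. Statements on the series, on what has been measured and on what is new or still open speak of the compounds shown alone.

Of the compounds shown here, three sharing one core have been measured in a functional assay on OVCAR-3 cells (Homo sapiens) for inhibition, read by MTT assay, with a stated time of 24 h; a lower number here means a stronger inhibitor, a higher number a weaker inhibitor. Compound 1 `CC1(C)[C@H]2CC[C@]1(C)N(Cc1cn(-c3ccccc3C#N)nn1)C(=O)C2` gives 110 nM, compound 2 `CC1(C)[C@H]2CC[C@]1(C)N(Cc1cn(-c3cccc(C#N)c3)nn1)C(=O)C2` gives 230 nM, and compound 3 `CC1(C)[C@H]2CC[C@]1(C)N(Cc1cn(-c3cccc(Cl)c3)nn1)C(=O)C2` gives 50 nM. Compound 2 thus stands highest of the three numbers, with a 2.1-fold higher number from compound 1 to compound 2 (0.32 log units; beyond the scatter) and a 4.6-fold lower number from compound 2 to compound 3 (0.66 log units; beyond the scatter). Compound 4 `CC1(C)[C@H]2CC[C@]1(C)N(Cc1cn(-c3cccc(Br)c3)nn1)C(=O)C2` differs from compound 2 by bromo in place of cyano on an aromatic carbon. The step that bears most closely on this change is a 4.6-fold lower number from compound 2 to compound 3 (0.66 log units; beyond the scatter), a modest move beyond the scatter when a halogen took the place of the nitrile. Bromo, like chloro, is a halogen, so a step of similar size is expected for compound 4: a 4.2-fold lower number from compound 2 to compound 4 (0.62 log units; beyond the scatter). Compound 4 is therefore estimated at 55 nM, with a range from 25 nM to 120 nM.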

Compound 4, half-maximal inhibitory concentration: 30 nM
Estimate against measurement, compound 4: 1.8-fold (0.26 log units) above, and the stated range covers the measured number.
By their numbers in this assay, from the lowest: compounds 4 and 3 (each within the scatter of the next); then compound 1; then compound 2.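

A second halogen now repeats the nitrile-to-halogen drop in this place, with a 7.7-fold lower number from compound 2 to compound 4 (0.88 log units; beyond the scatter) in this assay. Bromo and chloro cannot be told apart here, since a 1.7-fold lower number from compound 3 to compound 4 (0.22 log units; within the scatter) stays within the usual scatter. The 3-bromophenyl group also outdoes the 2-cyanophenyl group, with a 3.7-fold lower number from compound 1 to compound 4 (0.56 log units; beyond the scatter) on the same core.

Nothing available explains why the halogens and the nitrile differ. Going by these compounds, whether a methoxy group, an amine or a carboxylic acid in this place would track the halogens or the nitrile remains open.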